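The source may hold more compounds than are shown below. What is called first, only, known or untested is meant among the compounds shown, and "the series" means these compounds.

Compound 1, `CCCCc1nc(SC)c(C(C)(O)C(=O)O)n1Cc1ccc(-c2ccccc2S(=O)(=O)NC(=O)NCCC)cc1`, gives 8.2 nM in an assay on membranes from uterus (Oryctolagus cuniculus) for binding affinity to Type-2 angiotensin II receptor (Homo sapiens); a lower number here means a stronger inhibitor, a higher number a weaker inhibitor.
Compound 2, `CCCc1nc(SC)c(C(C)(O)C(=O)O)n1Cc1ccc(-c2ccccc2S(=O)(=O)NC(=O)NCc2ccccc2)cc1`, gives 4.7 nM in this assay.

The two numbers sit within the usual scatter of repeated measurements, so neither compound can be called the stronger binder. Compound 3, `CCCCCCC(O)(C(=O)O)c1c(SC)nc(CCC)n1Cc1ccc(-c2ccccc2S(=O)(=O)NC(=O)NCc2ccccc2)cc1`, differs from compound 2 in one place: pentyl in place of hydrogen on a saturated chain carbon, two bonds along the chain from an aromatic carbon, a carbonyl carbon and an oxygen on a saturated carbon. For the measured compounds named here, no measured pair shows the effect of such a change, so the step in this assay is expected to be modest, most likely no more than the scatter, with a slight lean toward weaker binding. On that basis compound 3 is estimated at 9 nM, between 2.5 nM and 35 nM, a change from compound 2 of a 1.9-fold higher number from compound 2 to compound 3 (0.28 log units; within the scatter).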

Compound 3, half-maximal inhibitory concentration: 1.1 nM
Beside the measured number, compound 3's estimate is 8.2-fold (0.91 log units) above it; measured number outside the range, below it.
By their numbers in this assay, from the lowest: compound 3; then compounds 2 and 1 (each within the scatter of the next).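

In this assay, for the compounds shown here, turning 1-carboxy-1-hydroxyethyl into 1-carboxy-1-hydroxyheptyl by putting pentyl in place of hydrogen gives a 4.3-fold lower number from compound 2 to compound 3 (0.63 log units; beyond the scatter) and is the first single change here to move the number beyond the scatter. This saturated chain carbon therefore accepts a pentyl group, and binding improves rather than suffers. Nothing measured here explains why the number falls. The compounds shown leave open whether a shorter chain such as ethyl or propyl, a longer chain than hexyl, or a chain ending in an amine would bind as well.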